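Ethyl for hydrogen on the amine nitrogen of compound 3

The source may hold more compounds than are shown below. What is called first, only, known or untested is meant among the compounds shown, and "the series" means these compounds.

The series is followed in a functional assay on Jurkat cells (Homo sapiens) for inhibition; on this read-out lower numbers stand for stronger inhibition and higher numbers for weaker inhibition. Compound 1 `CCCCCCCCCCCCCCC(CO)NCCCCCC` gives 6000 nM. Compound 2 `CCCCCCCCCCCCCCC(COCc1ccccc1)NC(=O)CCC(=O)O` gives 30000 nM. Compound 3 `CCCCCCCCCCCCCCC(CNCC)NC(=O)OC(C)(C)C` gives 6000 nM. Compound 3 stands level with compound 1 at the digits shown, the two together at the lowest number of the three; the gap between them lies within the scatter. Against compound 2 the number of compound 3 is lower, a gap beyond the scatter, so among these three only compound 2 separates from the rest.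

Compound 4 `CCCCCCCCCCCCCCC(CN(CC)CC)NC(=O)OC(C)(C)C` is not yet measured in this assay . It differs from compound 3 in one place: ethyl in place of hydrogen on an amine nitrogen, the ethylamino group becoming diethylamino. Within the data shown here, no pair of measured compounds shows this change, so there is nothing in the numbers to read its direction from. The step is expected to be small, with no change beyond the scatter as the likeliest outcome, which is what the expected step of a 1.3-fold higher number from compound 3 to compound 4 (0.12 log units; within the scatter) means. For compound 4 the estimate is 8000 nM, with a range from 2500 nM to 25000 nM.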

Compound 4, half-maximal inhibitory concentration: 21000 nM
Beside the measured number, compound 4's estimate is 2.6-fold (0.42 log units) below it, within the range that was stated.
By their numbers in this assay, from the lowest: compounds 1 and 3 (each within the scatter of the next); then compounds 4 and 2 (each within the scatter of the next).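

In this assay, among these compounds, the change from ethylamino to diethylamino gives the first comparison between compounds that differ in one place, and the step is a 3.5-fold higher number from compound 3 to compound 4 (0.54 log units; beyond the scatter). The amine nitrogen of compound 3 is therefore a place where this read-out responds to substitution, and a second ethyl there moves the number in the weaker direction, though only by a modest step. No independent data bearing on the origin of this step are at hand.

A single step leaves open whether the loss belongs to ethyl specifically or would also follow from a methyl, a longer chain such as propyl, or a ring such as pyrrolidine on the same nitrogen. It also leaves open whether the step keeps its direction and size when the rest of compound 3 changes, for instance with a free primary amine or a carboxylic acid elsewhere on the shared core.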